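Morpholine for piperazine on the sulfonyl of compound 2

The source may hold more compounds than are shown below. What is called first, only, known or untested is meant among the compounds shown, and "the series" means these compounds.

Within the data shown here, compound 2 `O=C(NCC1CCN(CCCS(=O)(=O)N2CCNCC2)CC1)c1cccc2c1OCCO2` gives 0.159 nM in an assay on isolated protein for inhibition of 5-hydroxytryptamine receptor 4 (Homo sapiens) (a lower number here means a stronger inhibitor, a higher number a weaker inhibitor), the highest of the two numbers known, with compound 1 `CC1(C)CCN(S(=O)(=O)CCCN2CCC(CNC(=O)c3cccc4c3OCCO4)CC2)CC1` nearest at 0.126 nM. The change to compound 3 `O=C(NCC1CCN(CCCS(=O)(=O)N2CCOCC2)CC1)c1cccc2c1OCCO2` is morpholin-4-yl in place of piperazin-1-yl on a sulfonyl sulfur. Among the measured compounds shown here, the only step at this sulfonyl sulfur, a 1.3-fold higher number from compound 1 to compound 2 (0.10 log units; within the scatter), stayed within the scatter, so a further swap of the ring on that sulfur is expected to move the number little. Compound 3 is therefore expected at 0.2 nM, between 0.07 nM and 0.6 nM, a step of a 1.3-fold higher number from compound 2 to compound 3 (0.10 log units; within the scatter) from compound 2 that is expected to lie within the scatter.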

Compound 3, inhibition constant: 0.398 nM
For compound 3 the middle estimate is 2.0-fold (0.30 log units) below the measured one; low and high end bracket the measured number.
By their numbers in this assay, from the lowest: compounds 1 and 2 (each within the scatter of the next); then compound 3.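

At this sulfonyl sulfur, the ring is not freely interchangeable in this assay: morpholin-4-yl in place of piperazin-1-yl gives a 2.5-fold higher number from compound 2 to compound 3 (0.40 log units; beyond the scatter), and morpholin-4-yl in place of 4,4-dimethylpiperidin-1-yl gives a 3.2-fold higher number from compound 1 to compound 3 (0.50 log units; beyond the scatter). Among these compounds, these are the first steps at this position to lie beyond the scatter, and they set compound 3 apart from compounds 1 and 2, though both remain modest. No evidence is available that accounts for the difference. On these data alone, it remains open whether a 4-methylpiperazin-1-yl ring or an open-chain dimethylamino group on the sulfonyl sulfur would fall with compounds 1 and 2 or with compound 3.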